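Dropping the Acetylphenoxy Group for a Plain Benzyl

The compounds below may be only part of what the source reports. "The series", "measured", "known", "first", "only" and "open" are said of these compounds alone.

Measured so far:
compound 2, `CC(=O)c1ccc(OCCCN2CCC(C(c3ccc(F)cc3)c3ccc(F)cc3)CC2)cc1`: 2.51 nM
compound 1, `COc1cc(C(C)=O)ccc1OCCCCCN1CCC(C(c2ccc(F)cc2)c2ccc(F)cc2)CC1`: 3.16 nM

Both compounds were measured in a functional assay (aorta) with Oryctolagus cuniculus as the target; on this read-out higher numbers stand for weaker binding and lower numbers for tighter binding. Compound 2 gives 2.51 nM and compound 1 gives 3.16 nM; the gap between them falls within the usual scatter of this kind of measurement, so on these two numbers compound 2 and compound 1 cannot be told apart. Compound 2 therefore stands at the low end of a pair that is, for practical purposes, one level.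

Compound 3, `Fc1ccc(C(c2ccc(F)cc2)C2CCN(CCCCc3ccccc3)CC2)cc1`, is the untested neighbour of compound 2. The change is benzyl in place of 4-acetylphenoxy on a saturated chain carbon, three bonds along the chain from an amine nitrogen in a ring. The shared core of compound 2 and compound 3, the two fluorinated aryl groups on the ring, is untouched; only the far end of the chain is altered, and the carbonyl and ether oxygen that made up both hydrogen-bond acceptors of the leaving group are gone.

Within the data shown here, no measured pair shows this kind of change, so any expectation rests on the two values alone. A modest move toward weaker binding is expected in this assay, a step of roughly a 3.2-fold higher number from compound 2 to compound 3 (0.50 log units; beyond the scatter), at the edge of the scatter rather than a collapse, since the shared core carries most of what the two measured compounds have in common. Compound 3 is thus estimated at 8 nM, with a plausible range from 2.5 nM to 25 nM.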

Compound 3, dissociation constant: 2.51 nM
Compound 3: the middle estimate sits 3.2-fold (0.50 log units) above what was measured, and the stated range covers the measured number.
By their numbers in this assay, from the lowest: compounds 2, 3 and 1 (each within the scatter of the next).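

In this assay the read-out shows no change at the digits printed from compound 2 to compound 3 (within the scatter) when benzyl takes the place of 4-acetylphenoxy on a saturated chain carbon, three bonds along the chain from an amine nitrogen in a ring. Among these compounds, the two earlier compounds differ in more than one place, so this is the first comparison here that isolates a single position, and it shows that the carbonyl and the ether oxygen can both leave this end of the chain with no change beyond the scatter on this read-out. Nothing at hand explains why the number holds level across this change.

As far as these compounds go, both groups carry a six-membered aromatic ring of carbon only, so it remains open whether that ring matters at this position, a question that a carboxylic acid or an amine in its place would help to answer. It also remains open how a longer chain would read with the benzyl end kept the same, since no pair shown changes the chain length alone.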